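Bromo for chloro on the fused ring of compound 3

A few compounds are considered here, and "the series" means these few. Any claim that something is new, unique, unknown or untested is made for them only; others in the source may bear on it.

Working notes on the series. Four compounds share one core. Among the measured compounds shown here, compound 1 `CCN(CC)CCCn1c(=O)c(=Cc2cc(OC)c(OC)c(OC)c2)s/c1=C1\C(=O)Nc2ccc(C)cc21` is the only one without a number in a functional assay on MDA-MB-231 cells (Homo sapiens) for inhibition, read by MTT assay, with a stated time of 72 h; a lower number here means a stronger inhibitor, a higher number a weaker inhibitor: for compound 1 the recorded value > 200000 nM is a limit of the assay, not a measurement. Compound 1 therefore sits at the limit of > 200000 nM in this assay, at which 1 of the 3 values shown sits, and is left out of the comparisons that follow.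

Compound 2 `CN(C)CCn1c(=O)c(=Cc2ccc(F)cc2F)s/c1=C1\C(=O)Nc2cc(F)ccc21` in this assay gives 8440 nM. Compound 3 `CN(C)CCn1c(=O)c(=Cc2ccc(O)cc2)s/c1=C1\C(=O)Nc2ccc(Cl)cc21` in this assay gives 3250 nM, the lowest of the two numbers available; the gap between compound 3 and compound 2 lies beyond the usual scatter, so compound 3 is the stronger inhibitor of the pair.

Compound 4 `CN(C)CCn1c(=O)c(=Cc2ccc(O)cc2)s/c1=C1\C(=O)Nc2ccc(Br)cc21` has not been measured. It differs from compound 3 by bromo in place of chloro on an aromatic carbon. For the measured compounds named here, no pair of measured compounds in the set carries this exchange, so no measured step can be quoted for it. The expectation rests on the change itself: one halogen replaced by another on the same aromatic carbon, with no ring, donor, acceptor or charge added or removed. A step no larger than the scatter is expected in this assay, in no particular direction.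

Compound 4 is therefore estimated at 3000 nM in this assay, with a range from 1200 nM to 8000 nM. This estimate implies a step of a 1.1-fold lower number from compound 3 to compound 4 (0.03 log units; within the scatter), expected to stay within the scatter.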

Compound 4, half-maximal inhibitory concentration: 2520 nM
The estimate for compound 4 lay 1.2-fold (0.08 log units) above the measured number; low and high end bracket the measured number.
By their numbers in this assay, from the lowest: compounds 4 and 3 (each within the scatter of the next); then compound 2. At a limit, above all of these: compound 1.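

Bromo in place of chloro, on an aromatic carbon meta to a fused ring and para to a fused ring, gives in this assay a 1.3-fold lower number from compound 3 to compound 4 (0.11 log units; within the scatter), the only step in the series so far between two compounds that differ in one place. This position therefore takes the larger halogen with no change that can be told from the scatter, and compound 3 and compound 4 can be treated as one level in this assay when further changes are compared. The exchange adds or removes no ring, donor, acceptor or charge, and nothing measured in the series accounts for the outcome or says what this position contributes to the values.

The compounds shown leave open whether this carbon accepts a group of another kind, such as a nitrile, a carboxylic acid or an amine, or whether the flat response holds only between the two halogens. They also leave open whether the same exchange behaves alike when the dimethylamino end of the side chain gives way to a morpholine, or when the hydroxy group gives way to a carboxylic acid.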